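The source may report more compounds than this note shows. Statements on the series, on what has been measured and on what is new or still open speak of the compounds shown alone.

Compound 1 `CC1=C(C(=O)OC(C)(C)C)C(c2ccco2)NC(=O)N1` gives 44% in an assay on HEK293 cells for displacement of a labelled ligand from adenosine receptor A2b (Homo sapiens), with a stated time of 30 min, tested at 10 uM; on this read-out higher numbers stand for more inhibition at the one concentration tested (going by the name of the read-out) and lower numbers for less inhibition.
Compound 2 `CCOC(=O)C1=C(c2ccccc2)NC(=O)NC1c1ccco1` gives 28% in this assay.
Compound 3 `CCOC(=O)C1=C(C)N(C)C(=O)NC1c1cccs1` gives 11% in this assay.

These three compounds differ from one another in several places at once, so no single change can be read from their numbers. Compound 3 stands lowest of the three: compound 2 is nearest, with a number beyond the scatter above it, and compound 1 is furthest, also beyond the scatter above it.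

Compound 4 `CC1=C(C(=O)OC(C)C)C(c2cccs2)NC(=O)N1C` is built on the core of compound 3 and differs from it in one place only: methyl in place of hydrogen on a saturated chain carbon bound to an oxygen next to a carbonyl group and a saturated chain carbon. Within the data shown here, no pair of measured compounds shows what such a change does, so the expectation rests on compound 3 alone. Swapping a small ester group for a slightly larger one of the same kind is expected to move the number little, and the step from compound 3 to compound 4 is expected to lie within the scatter, as a number 4 percentage points higher from compound 3 to compound 4 (within the scatter). Compound 4 is therefore expected to give about 15% in this assay, between 0% and 35%.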

Compound 4, a percentage reported as inhibition, at one concentration (the size of the read-out at that concentration, not a potency): 28%
For compound 4 the middle estimate is 13 percentage points below the measured one; the measured number falls inside the stated range.
By their numbers in this assay, from the lowest: compound 3; then compounds 2 and 4 (each within the scatter of the next); then compound 1.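

Changing ethoxycarbonyl to isopropoxycarbonyl gives a number 17 percentage points higher from compound 3 to compound 4 (beyond the scatter) in this assay. Among these compounds, this is the first comparison here in which only one place differs, and it shows that a single added methyl, on a saturated chain carbon bound to an oxygen next to a carbonyl group and a saturated chain carbon, can shift the number by more than the usual scatter. No separate measurement is available to explain this rise.

A single step cannot show whether the number would continue to rise with other ester groups, such as a longer butyl chain, or what a carboxylic acid or an amide would give in the same place. It also leaves open whether the same change would have a similar effect on the cores of compound 1 or compound 2.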